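Moving the quinazoline attachment point and adding a fluorine

The compounds below may be only part of what the source reports. "The series", "measured", "known", "first", "only" and "open" are said of these compounds alone.

Measured so far:
compound 1 `Cc1ccc(-n2nccn2)c(C(=O)N2C[C@@H]3CN(c4nc5ccccc5n4C)C[C@@H]3C2)c1` gives 775 nM
compound 2 `Cc1ccc(-n2nccn2)c(C(=O)N2C[C@@H]3CN(c4ncnc5ccccc45)C[C@@H]3C2)c1` gives 1690 nM

Both were tested in a functional assay on HEK293 cells for antagonist activity at Orexin receptor type 2 (Homo sapiens), read by FLIPR and calcium flux, with a stated time of 60 min; on this read-out lower numbers stand for stronger inhibition and higher numbers for weaker inhibition. Among the measured compounds shown here, compound 2 gives the higher of the two numbers; the only measured step, a 2.2-fold higher number from compound 1 to compound 2 (0.34 log units; beyond the scatter), is modest. Compound 3 `Cc1ccc(-n2nccn2)c(C(=O)N2C[C@@H]3CN(c4ncc5cc(F)ccc5n4)C[C@@H]3C2)c1` is not yet measured. It differs from compound 2 in one place: 6-fluoroquinazolin-2-yl in place of quinazolin-4-yl on an amine nitrogen in a ring. For the measured compounds named here, no measured step covers this change, so the expectation rests only on compound 2 and on the size of the one known step. The estimate for compound 3 is a step of a 1.9-fold lower number from compound 2 to compound 3 (0.27 log units; within the scatter), giving an expected value of 900 nM, with a range from 300 nM to 3000 nM.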

Compound 3, half-maximal inhibitory concentration: 108 nM
Beside the measured number, compound 3's estimate is 8.3-fold (0.92 log units) above it, and the stated range ends above it.
By their numbers in this assay, from the lowest: compound 3; then compound 1; then compound 2.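

The group on this amine nitrogen in a ring can shift the number much further than the earlier swap showed: 6-fluoroquinazolin-2-yl in place of quinazolin-4-yl brings a 16-fold lower number from compound 2 to compound 3 (1.19 log units; beyond the scatter) and in place of 1-methyl-1H-benzimidazol-2-yl brings a 7.2-fold lower number from compound 1 to compound 3 (0.86 log units; beyond the scatter) with the rest of the molecule unchanged. Compound 3 therefore has the lowest number of the three, with both steps beyond the scatter. No supporting data explain this gain. Going by these compounds, the new attachment point and the fluorine arrive together, so the share of each remains open. Plain quinazolin-2-yl, without fluorine, or 6-chloroquinazolin-2-yl would help separate them.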